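This account rests on a few compounds, and the source may have more. Where it says the series, first, only, none or still open, it means among the compounds named here.

Measured compounds:
compound 1, `C#CCNC1CCc2c(SCCc3cccc(Br)c3)cccc21` — 30500 nM in an assay on isolated protein for inhibition of Amine oxidase [flavin-containing] B (Homo sapiens); a higher number here means a weaker inhibitor, a lower number a stronger inhibitor
compound 2, `C#CCNC1CCc2c(SCc3cccc(Br)c3)cccc21` — > 100000 nM

Going by the values given here, compound 1 stands as the only numerical value shown. The other entry is the limit of > 100000 nM in this assay, at which 1 of the 2 values shown sits. Compound 2 gives > 100000 nM, which is a limit of the assay rather than a number. Both compounds share the same core, and compound 1 carries the longer saturated chain to its aromatic ring. Compound 3, `C#CCNC1CCc2c(SCCc3ccc(OC)cc3)cccc21`, has not yet been measured. It differs from compound 1 by 4-methoxyphenyl in place of 3-bromophenyl on a saturated chain carbon, two bonds along the chain from a sulfur. Among the compounds with values here, with no measured step between two compounds available, the size of the change cannot be read off from the data, so no step beyond the usual scatter is assumed in this assay, in either direction. Compound 3 is expected to give about 45000 nM, with a range from 10000 nM to 200000 nM. This estimate amounts to an expected 1.5-fold higher number from compound 1 to compound 3 (0.17 log units; within the scatter).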

Compound 3, half-maximal inhibitory concentration: 62000 nM
The estimate for compound 3 lay 1.4-fold (0.14 log units) below the measured number, within the range that was stated.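

Going by these compounds alone, this is the first readable step at this position: in this assay, 4-methoxyphenyl in place of 3-bromophenyl gives a 2.0-fold higher number from compound 1 to compound 3 (0.31 log units; beyond the scatter). The group carried on the saturated chain therefore does register in the read-out, although the step is modest and lies only just beyond the usual scatter. The change alters both the substituent and its place on the ring, and these data do not separate the two.

Steps involving compound 2 cannot be read, as compound 2 stands at a limit of the assay and not at a number: the limit of > 100000 nM in this assay, at which 1 of the 3 values shown sits. Still open is how 3-methoxyphenyl or 4-bromophenyl would read on the same chain, and whether a longer chain or an amine on the ring would shift the number further.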